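Cyclohexyl to phenyl on the oxygen: compound 4

The source may hold more compounds than are shown below. What is called first, only, known or untested is meant among the compounds shown, and "the series" means these compounds.

Measured so far in a functional assay on MCF7 cells (Homo sapiens) for inhibition, read by sulforhodamine B assay, with a stated time of 48 h; on this read-out higher numbers stand for weaker inhibition of growth and lower numbers for stronger inhibition of growth:
- compound 1 `c1cc(NC2=NCCO2)cc(OC2CCCCC2)c1`: 15900 nM
- compound 2 `c1ccc(Oc2cccc(NC3=NCCO3)c2)cc1`: 12200 nM
- compound 3 `O=C(CCl)NC(=O)Nc1cccc(OC2CCCCC2)c1`: 6300 nM

Compound 3 has the lowest of the three numbers. Its nearest neighbour is compound 2, whose number is higher but within the scatter, so no order between compound 3 and compound 2 is claimed. Against compound 1 the gap is real: a 2.5-fold lower number from compound 1 to compound 3 (0.40 log units; beyond the scatter).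

Compound 4 `O=C(CCl)NC(=O)Nc1cccc(Oc2ccccc2)c1` differs from compound 3 in one place: phenyl in place of cyclohexyl on an oxygen on an aromatic ring. For the measured compounds named here, one measured step bears directly on this change, made on the core of compound 1 rather than compound 3: a 1.3-fold lower number from compound 1 to compound 2 (0.12 log units; within the scatter). That step stayed within the scatter, and nothing else in the series speaks to the change, so the same exchange on compound 3 is expected to give no step beyond the scatter in this assay: a 1.3-fold lower number from compound 3 to compound 4 (0.10 log units; within the scatter). Compound 4 is therefore estimated at 5000 nM, with a range from 2500 nM to 11000 nM; whether the number lands on either side of compound 3 cannot be told from one within-scatter step.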

Compound 4, concentration for 50% growth inhibition: 8100 nM
Estimate against measurement, compound 4: 1.6-fold (0.21 log units) below; measured number inside the range.
By their numbers in this assay, from the lowest: compounds 3, 4, 2 and 1 (each within the scatter of the next, the first and the last beyond it).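

With compound 4, the exchange of cyclohexyl for phenyl on an oxygen on an aromatic ring can be read on two cores in this assay. On the second core the step is a 1.3-fold higher number from compound 3 to compound 4 (0.11 log units; within the scatter), so across both cores the exchange produces no step beyond the scatter: the same change on two cores in this assay, a 1.3-fold lower number (0.12 log units; within the scatter) from compound 1 to compound 2 and a 1.3-fold higher number (0.11 log units; within the scatter) from compound 3 to compound 4, 1.7-fold (0.22 log units) apart, within the scatter of two such steps. The ring-free group on a nitrogen on an aromatic ring can now also be read with phenoxy in place of cyclohexyloxy, where the step is a 1.5-fold lower number from compound 2 to compound 4 (0.18 log units; within the scatter), so the step beyond the scatter from the cyclohexyloxy pair does not recur, although the two steps do not separate: the same change on two cores in this assay, a 2.5-fold lower number (0.40 log units; beyond the scatter) from compound 1 to compound 3 and a 1.5-fold lower number (0.18 log units; within the scatter) from compound 2 to compound 4, 1.7-fold (0.22 log units) apart, within the scatter of two such steps.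

Open, from the compounds shown here alone, is whether a benzyl group or a short alkyl chain on the oxygen would give a step beyond the scatter in this assay. Also open, going by these compounds, is what happens to the number when a methyl group or an amine replaces the chlorine of the ring-free group.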